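The source may report more compounds than this note shows. Statements on the series, on what has been measured and on what is new or still open speak of the compounds shown alone.

Of the compounds shown here, three on one shared core have been tested in a functional assay on BXPC-3 cells (Homo sapiens) for antiproliferative activity, read by MTT assay, with a stated time of 24 h (a lower number here means a stronger inhibitor, a higher number a weaker inhibitor), and they differ only in the group on an amide-type nitrogen. Compound 1 `CCn1c(C(=O)N[C@@H](CC(=O)OC)C(=O)OC)ccc1C(CC)(CC)c1ccc(OCS(=O)(=O)c2ccccc2)c(C)c1`, with 1,2-bis(methoxycarbonyl)ethyl there, gives > 50000 nM, which is a limit of the assay and not a number. Compound 2 `CCn1c(C(=O)NCCO)ccc1C(CC)(CC)c1ccc(OCS(=O)(=O)c2ccccc2)c(C)c1`, with 2-hydroxyethyl, gives 19900 nM, and compound 3 `CCn1c(C(=O)N[C@@H](CO)C(C)C)ccc1C(CC)(CC)c1ccc(OCS(=O)(=O)c2ccccc2)c(C)c1`, with 1-(hydroxymethyl)-2-methylpropyl, gives 13200 nM.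

Compound 3 therefore stands level with compound 2, since a 1.5-fold lower number from compound 2 to compound 3 (0.18 log units; within the scatter) does not separate them. Both stand clear of compound 1: the data show an at least 2.5-fold lower number from compound 1 to compound 2 (0.40 log units; beyond the scatter) and an at least 3.7-fold lower number from compound 1 to compound 3 (0.57 log units; beyond the scatter).

Compound 4 `CCn1c(C(=O)N[C@H](CO)CCCO)ccc1C(CC)(CC)c1ccc(OCS(=O)(=O)c2ccccc2)c(C)c1` has not yet been measured. Its change is a group of 7 heavy atoms (5 carbon, 2 oxygen; no ring) in place of a group of 6 heavy atoms (5 carbon, 1 oxygen; no ring), on an amide-type nitrogen, and neither group carries a ring or a net charge. The closest guide is the step that added isopropyl to the chain, and no large move is expected because a 1.5-fold lower number from compound 2 to compound 3 (0.18 log units; within the scatter) stayed small. The two larger steps both started from the group in compound 1, which is not involved here. The expected change is therefore none beyond the scatter, with a slight lean towards a higher number: a 1.4-fold higher number from compound 3 to compound 4 (0.13 log units; within the scatter). The estimated value for compound 4 is 18000 nM, with an expected range of 8000 nM to 40000 nM.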

Compound 4, half-maximal inhibitory concentration: > 50000 nM
Compound 4: only a limit was reported; the forecaster's own chance of this, stated with the estimate: 10%; middle value at least 2.7-fold (0.44 log units) away from the limit.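

In this assay compound 4 gives > 50000 nM, which is a limit of the assay and not a number. Isopropyl and 3-hydroxypropyl both go on the same saturated chain carbon of compound 2, yet they do not read alike: isopropyl gives a 1.5-fold lower number from compound 2 to compound 3 (0.18 log units; within the scatter), whereas 3-hydroxypropyl gives an at least 2.5-fold higher number from compound 2 to compound 4 (0.40 log units; beyond the scatter), and exchanging the two groups gives an at least 3.7-fold higher number from compound 3 to compound 4 (0.57 log units; beyond the scatter). Among these compounds, the earlier compounds showed a step beyond the scatter only when leaving the 1,2-bis(methoxycarbonyl)ethyl group of compound 1, so this is the first sign that a modest change among the hydroxyl-bearing groups on the amide-type nitrogen can also move the number beyond the scatter.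

From the compounds shown here alone, the step between compound 1 and compound 4 cannot be read, and the full size of the two steps to compound 4 remains unknown, because both compounds stop at the same limit: the limit of > 50000 nM in this assay, at which 2 of the 4 values shown sit. Also open is whether the hydroxyl at the end of the 3-hydroxypropyl chain drives this loss, and how an amine, a carboxylic acid or a longer chain without a hydroxyl would read on the same carbon.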